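The compounds below may be only part of what the source reports. "The series", "measured", "known", "first", "only" and "open" are said of these compounds alone.

Compound 1 `Cc1cn(C2CC(N=[N+]=[N-])C(COC(=O)OCCCCCCCCO)O2)c(=O)[nH]c1=O` gives > 50000 nM in a functional assay on MT4 cells (Homo sapiens) for cytotoxicity (a higher number here means that more compound is tolerated, a lower number that less compound is tolerated), which is a limit of the assay rather than a number.
Compound 2 `Cc1cn(C2CC(N=[N+]=[N-])C(COC(=O)NCCCO)O2)c(=O)[nH]c1=O` gives > 50000 nM in this assay, again a limit of the assay.
Compound 3 `Cc1cn(C2CC(N=[N+]=[N-])C(COC(=O)CCCC(=O)O)O2)c(=O)[nH]c1=O` gives > 50000 nM in this assay, also a limit of the assay.

The three measured compounds share one core and differ only in the chain that hangs off the carbonyl carbon. Compound 2 stands where every other measured compound stands: at the upper edge of what the assay can report, so no ranking among them is possible. Compound 4 `Cc1cn(C2CC(N=[N+]=[N-])C(COC(=O)OCCCCCO)O2)c(=O)[nH]c1=O` takes the change ((5-hydroxypentyl)oxy in place of (3-hydroxypropyl)amino on a carbonyl carbon). Within the data shown here, the steps that bear on it are a step that the two limits leave unreadable from compound 1 to compound 2 and a step that the two limits leave unreadable from compound 2 to compound 3, both of which the limits leave unreadable, and the same holds for a step that the two limits leave unreadable from compound 1 to compound 3. Since all measured values sit together at the limit of > 50000 nM in this assay, at which 3 of the 3 values shown sit, no direction or size can be read for the change to compound 4. The expectation is therefore that compound 4 also reaches the limit, giving an estimate of 50000 nM with a range from 30000 nM to 100000 nM, corresponding to an expected step of a number no higher from compound 2 to compound 4 (the limit leaves the size open).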

Compound 4, half-maximal cytotoxic concentration: > 50000 nM
Compound 4: only a limit was reported; the forecaster's own chance of this, stated with the estimate: 85%; the middle value sits exactly at the limit.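

Compound 4 sits at the same limit of the assay as compound 1, compound 2 and compound 3, so no step among these compounds can be read: the limit of > 50000 nM in this assay, at which 4 of the 4 values shown sit.

The compounds shown leave open whether any of these chains on the shared core differs from another in how much compound the cells tolerate.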